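Swapping the thiophen-2-yl group of compound 3

The source may report more compounds than this note shows. Statements on the series, on what has been measured and on what is new or still open speak of the compounds shown alone.

In an ADME assay on HepG2 2.2.15 cells (Homo sapiens) for cytotoxicity, read by MTT assay (on this read-out lower numbers stand for higher toxicity in this test and higher numbers for lower toxicity in this test), compound 1 (`C=C1CC[C@@H]2[C@](C)(COC(=O)c3cccnc3)[C@H](O)CC[C@@]2(C)[C@@H]1/C=C/C1=CCOC1=O`) gives 113000 nM as the lowest number, compound 2 (`C=C1CC[C@@H]2[C@](C)(COC(=O)c3ccc(OC)nc3)[C@H](O)CC[C@@]2(C)[C@@H]1/C=C/C1=CCOC1=O`) gives 1340000 nM as the highest, and compound 3 (`C=C1CC[C@@H]2[C@](C)(COC(=O)c3cccs3)[C@H](O)CC[C@@]2(C)[C@@H]1/C=C/C1=CCOC1=O`) stands second highest with 557000 nM on this scale. Compound 4 (`C=C1CC[C@@H]2[C@](C)(COC(=O)c3cc(=O)c4ccccc4o3)[C@H](O)CC[C@@]2(C)[C@@H]1/C=C/C1=CCOC1=O`) shares the core and differs from compound 3 by a group of 11 heavy atoms (9 carbon, 2 oxygen; one six-membered aromatic ring of carbon only, one six-membered aromatic ring with 1 hetero atom) in place of a group of 5 heavy atoms (4 carbon, 1 sulfur; one five-membered aromatic ring with 1 hetero atom), on a carbonyl carbon and nothing else.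

Changes around this aromatic group have already moved the number. The data show a 12-fold higher number from compound 1 to compound 2 (1.07 log units; beyond the scatter) as a large step, while a 4.9-fold higher number from compound 1 to compound 3 (0.69 log units; beyond the scatter) and a 2.4-fold lower number from compound 2 to compound 3 (0.38 log units; beyond the scatter) are modest ones. These steps run in both directions, and none of them brings in a group of this size, so the direction remains uncertain. With compound 3 at 557000 nM near the top of these numbers, a modest step towards lower numbers in this assay is expected. The expected change is a 2.2-fold lower number from compound 3 to compound 4 (0.35 log units; beyond the scatter) on this estimate. For compound 4 the estimated value is 250000 nM with an expected range from 70000 nM to 900000 nM in repeat measurements.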

Compound 4, half-maximal cytotoxic concentration: 171000 nM
Compound 4: middle estimate off by 1.5-fold (0.16 log units), on the high side, and the stated range covers the measured number.
By their numbers in this assay, from the lowest: compounds 1 and 4 (each within the scatter of the next); then compound 3; then compound 2.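

In this assay, the largest group at this place, on a carbonyl carbon, does not carry the number upwards: a 3.3-fold lower number from compound 3 to compound 4 (0.51 log units; beyond the scatter) and a 7.8-fold lower number from compound 2 to compound 4 (0.89 log units; beyond the scatter). The third comparison, a 1.5-fold higher number from compound 1 to compound 4 (0.18 log units; within the scatter), stays within the scatter, so the two-ring group cannot be told apart from the pyridin-3-yl group of compound 1. Across these four compounds, the number does not follow group size, since the 8-atom group of compound 2 gives the highest number, while the 6-atom and 11-atom groups of compound 1 and compound 4 stand together at the low end.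

As far as these compounds go, it remains open how a plain phenyl group or a longer alkyl chain on the same carbonyl carbon would read in this assay. No measurement given here accounts for these differences.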